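A Nitro Group on the Phenylsulfonyl Ring of Compound 3

The source may report more compounds than this note shows. Statements on the series, on what has been measured and on what is new or still open speak of the compounds shown alone.

In an ADME assay on cells (Hepatocyte, Mus musculus) for cytotoxicity, read by MTT assay, with a stated time of 24 h (on this read-out lower numbers stand for higher toxicity in this test and higher numbers for lower toxicity in this test), compound 1 `FC(F)(F)c1ccc(-c2nn(-c3ccccc3)cc2-c2nc3ccccc3[nH]2)cc1` gives 159000 nM and compound 3 `O=S(=O)(c1ccccc1)n1c(-c2cn(-c3ccccc3)nc2-c2ccc(C(F)(F)F)cc2)nc2ccccc21` gives 186000 nM, so these two numbers sit within the scatter of each other. The step between them, a 1.2-fold higher number from compound 1 to compound 3 (0.07 log units; within the scatter), places phenylsulfonyl in place of hydrogen on an aromatic nitrogen. Compound 4 `O=[N+]([O-])c1ccc(S(=O)(=O)n2c(-c3cn(-c4ccccc4)nc3-c3ccc(C(F)(F)F)cc3)nc3ccccc32)cc1` differs from compound 3 by nitro in place of hydrogen on an aromatic carbon, para to a large group, turning phenylsulfonyl into (4-nitrophenyl)sulfonyl: nitro in place of hydrogen on an aromatic carbon. For the measured compounds named here, no measured step covers this change directly. Compound 2 `O=[N+]([O-])c1ccc(S(=O)(=O)n2c(-c3cn(-c4ccccc4)nc3-c3ccc(F)cc3)nc3ccccc32)cc1`, which carries the same (4-nitrophenyl)sulfonyl group, reads > 300000 nM in this assay, and that is a limit of the assay, not a number. Going by the values given here, with only that limit for compound 2 and the small measured step of a 1.2-fold higher number from compound 1 to compound 3 (0.07 log units; within the scatter) as guides, a small move toward higher numbers is expected, an estimated 1.3-fold higher number from compound 3 to compound 4 (0.13 log units; within the scatter). For compound 4 the estimate is 250000 nM, with an expected range from 130000 nM to 450000 nM.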

Compound 4, half-maximal cytotoxic concentration: 178000 nM
Compound 4: middle estimate off by 1.4-fold (0.15 log units), on the high side; measured number inside the range.
By their numbers in this assay, from the lowest: compounds 1, 4 and 3 (each within the scatter of the next). At a limit, above all of these: compound 2.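

In this assay, nitro in place of hydrogen on an aromatic carbon of the phenylsulfonyl ring, para to a large group, gives a step that stays within the scatter: a 1.0-fold lower number from compound 3 to compound 4 (0.02 log units; within the scatter). The (4-nitrophenyl)sulfonyl group in place of hydrogen on an aromatic nitrogen likewise stays within the scatter, as phenylsulfonyl did: a 1.1-fold higher number from compound 1 to compound 4 (0.05 log units; within the scatter). Compound 2 stands at a limit, so trifluoromethyl in place of fluoro on an aromatic carbon reads only as a floor, an at least 1.6-fold lower number from compound 2 to compound 4 (0.22 log units; that floor lies within the scatter), and its true size stays unknown: the limit of > 300000 nM in this assay, at which 1 of the 4 values shown sits.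

The compounds shown leave open whether an amine or a carboxylic acid in place of the nitro would also stay within the scatter of compound 3. They also leave open how a compound with fluoro and phenylsulfonyl would read.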